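This account rests on a few compounds, and the source may have more. Where it says the series, first, only, none or still open, it means among the compounds named here.

Among the measured compounds shown here, in a functional assay on NCI-H1975 cells (Homo sapiens) for inhibition, with a stated time of 72 h (a lower number here means a stronger inhibitor of growth, a higher number a weaker inhibitor of growth), compound 2 `CCCN(Cc1ccc(C(=O)NO)cc1)C(=O)c1cc(Cl)c(O)cc1O` gives 73600 nM, at the high end of the numbers so far and level with compound 3 `CCCCN(Cc1ccc(C(=O)NO)cc1)C(=O)c1cc(Cl)c(O)cc1O` at 66400 nM. Compound 1 `CCN(Cc1ccc(C(=O)NO)cc1)C(=O)c1cc(Cl)c(O)cc1O` gives 13200 nM, the lowest number. Compound 4 `CCCN(Cc1ccc(C(=O)NO)cc1)C(=O)c1cc(C(C)C)c(O)cc1O` carries a different kind of change: isopropyl in place of chloro on an aromatic carbon. The measured steps all concern the chain on the amide nitrogen, and the largest, a 5.6-fold higher number from compound 1 to compound 2 (0.75 log units; beyond the scatter), is modest. None of them touches this aromatic carbon, so they offer only a rough guide to size, and the direction is a tentative guess. The expected change in this assay is a modest one toward a lower number, a 3.7-fold lower number from compound 2 to compound 4 (0.57 log units; beyond the scatter). For compound 4 the estimate is 20000 nM, with an expected range from 3000 nM to 80000 nM.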

Compound 4, concentration for 50% growth inhibition: 23700 nM
Compound 4: middle estimate off by 1.2-fold (0.07 log units), on the low side; measured number inside the range.
By their numbers in this assay, from the lowest: compounds 1 and 4 (each within the scatter of the next); then compounds 3 and 2 (each within the scatter of the next).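

In this assay isopropyl in place of chloro gives a 3.1-fold lower number from compound 2 to compound 4 (0.49 log units; beyond the scatter) and so shows that this aromatic carbon, ortho to a hydroxy group and para to a hydroxy group, also moves the number, not only the chain on the amide nitrogen. Three carbon heavy atoms stand here in place of one chlorine, and growth inhibition gets stronger rather than being lost. Nothing at hand explains this step. From the compounds shown here alone, whether a methyl, a tert-butyl or an amine on this carbon would go further stays open. So does whether isopropyl gives a similar step with the shorter ethyl chain of compound 1.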